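Seeking Higher Oral Exposure by Trimming a Sulfonyl Substituent

The compounds below may be only part of what the source reports. "The series", "measured", "known", "first", "only" and "open" are said of these compounds alone.

In an in vivo ADME assay on the whole organism (strain BALB/c) for pharmacokinetics, with Mus musculus as the target, read by LC-MS, at a dose of 5 mg/kg by the oral route (on this read-out higher numbers stand for higher oral bioavailability and lower numbers for lower oral bioavailability), compound 3 (`COCCNS(=O)(=O)c1ccc(C)c(C#Cc2cc(Cl)ccc2OCC(=O)O)c1`) gives 33%, the lowest of the three measured values. Compound 1 (`CC(C)S(=O)(=O)c1ccc(Cl)c(C#Cc2cc(Cl)ccc2OCC(=O)O)c1`) reaches 64% and compound 2 (`CN(C)S(=O)(=O)c1cncc(C#Cc2cc(Cl)ccc2OCC(=O)O)c1`) reaches 95%, both beyond the scatter from compound 3. Compound 4 (`Cc1ccc(S(C)(=O)=O)cc1C#Cc1cc(Cl)ccc1OCC(=O)O`) carries methyl in place of (2-methoxyethyl)amino on a sulfonyl sulfur. For the measured compounds named here, no measured pair isolates this change, so the expectation is tentative. It leans on compound 1 at 64%, which like compound 4 has no amino group on its sulfonyl sulfur. A rise beyond the scatter is expected in this assay, estimated as a number 25 percentage points higher from compound 3 to compound 4 (beyond the scatter). For compound 4 the expected value is 58%, within an estimated range of 35% to 82%.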

Compound 4, oral bioavailability: 49%
Beside the measured number, compound 4's estimate is 9 percentage points above it, within the range that was stated.
By their numbers in this assay, from the lowest: compound 3; then compound 4; then compound 1; then compound 2.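

At the sulfonyl sulfur, methyl in place of (2-methoxyethyl)amino gives in this assay a number 16 percentage points higher from compound 3 to compound 4 (beyond the scatter), a modest step and the first to isolate a single place in this series. It shows that this substituent bears on oral bioavailability and that the (2-methoxyethyl)amino group is not required to retain it. Nothing measured here explains the step.

As far as these compounds go, whether the step follows the loss of the nitrogen or the shortening of the chain remains open. A 2-methoxyethyl group bound directly to the sulfur, or a plain amino group there, would separate the two.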